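The source may report more compounds than this note shows. Statements on the series, on what has been measured and on what is new or still open speak of the compounds shown alone.

Compound 1 `CCCC/C=C\CCCCCCCCCc1cc(=O)c2c(O)cc(O)c(C)c2o1` gives 17500 nM
Compound 2 `CC/C=C\C/C=C\C/C=C\CCCCCCCc1cc(=O)c2c(O)cc(O)cc2o1` gives 17500 nM

Both values come from a functional assay on MCF7 cells (Homo sapiens) for antiproliferative activity, read by MTT assay; on this read-out higher numbers stand for weaker inhibition and lower numbers for stronger inhibition. On these numbers, compound 2 stands level with compound 1, so the two cannot be told apart. The next compound to be tested, compound 3 `CCCC/C=C\CCCCCCCCCc1cc(=O)c2c(O)cc(O)cc2o1`, differs from compound 2 only in its chain: a group of 8 heavy atoms (8 carbon; no ring) in place of a group of 10 heavy atoms (10 carbon; no ring), on a saturated chain carbon, seven bonds along the chain from an aromatic carbon. An oct-3-en-1-yl group enters on a saturated chain carbon, seven bonds along the chain from an aromatic carbon, and the rest of compound 2 stays as it is.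

Within the data shown here, no measured pair shows this exact change, so the data give no direct guide to its size. Among the measured compounds shown here, the only evidence is indirect: with compound 1 at 17500 nM and compound 2 at 17500 nM, the two values show no gap. No step beyond the usual scatter is therefore expected in this assay, in either direction. The expected step is no change at the digits printed from compound 2 to compound 3 (within the scatter). For compound 3 the estimated value is 17500 nM, with an expected range from 8000 nM to 38000 nM.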

Compound 3, half-maximal inhibitory concentration: 17500 nM
Compound 3: middle estimate and measured number agree at the digits printed; measured number inside the range.
By their numbers in this assay, from the lowest: compounds 1, 2 and 3 (each within the scatter of the next).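

In this assay, a group of 10 heavy atoms with 3 double bonds gives way to oct-3-en-1-yl, with 1 double bond, on a saturated chain carbon, seven bonds along the chain from an aromatic carbon, and the result is no change at the digits printed from compound 2 to compound 3 (within the scatter), so this read-out does not separate these two chains. Compound 3 also provides the first direct test of the methyl group on an aromatic carbon: hydrogen in place of methyl gives no change at the digits printed from compound 1 to compound 3 (within the scatter), so this methyl group makes no difference that can be read here, at least with this chain attached. Nothing else measured on these compounds helps to explain why all of these values match.

On these data alone, with only these three compounds, it remains open how much the chain or that aromatic carbon can be altered before the value moves away from this shared level. A fully saturated chain, a much shorter or longer chain, an amine or carboxylic acid at the chain end, or a chlorine atom in place of the methyl group could each test this further.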